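Hydroxy to Methoxy at an Assay Limit

A few compounds are considered here, and "the series" means these few. Any claim that something is new, unique, unknown or untested is made for them only; others in the source may bear on it.

Compound 1 `O=C(Nc1ccc(Sc2nc3ccccc3s2)c(Cl)c1)c1cc(Br)cc(Br)c1`: in an assay for inhibition of HSP60/HSP10 (Homo sapiens), with a stated time of 60 min (on this read-out lower numbers stand for stronger inhibition and higher numbers for weaker inhibition), compound 1 gives > 100000 nM, which is a limit of the assay.
Compound 2 `COc1c(Br)cccc1C(=O)Nc1ccc(Sc2nc3ccccc3s2)c(Cl)c1`: in this assay compound 2 gives > 100000 nM, again a limit.
Compound 3 `O=C(Nc1ccc(Sc2nc3ccccc3s2)c(Cl)c1)c1cc(Br)ccc1O`: in this assay compound 3 gives > 100000 nM, also a limit.

Compound 3 therefore stands only at a limit, and the two other values shown are limits as well, so none of the three compounds can be ordered against another. The steps among them, a step that the two limits leave unreadable from compound 1 to compound 2, a step that the two limits leave unreadable from compound 1 to compound 3 and a step that the two limits leave unreadable from compound 2 to compound 3, cannot be read because of the limit of > 100000 nM in this assay, at which 3 of the 3 values shown sit.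

Compound 4 `COc1ccc(Br)cc1C(=O)Nc1ccc(Sc2nc3ccccc3s2)c(Cl)c1` differs from compound 3 by methyl in place of hydrogen on an oxygen on an aromatic ring. Going by the values given here, the measured steps bear on this change only in that every variation so far of the group on the carbonyl carbon has left the value at the limit, and compound 2, which already carries a methoxy, is among them. Since no step can be read, no size or direction is expected beyond the scatter. Compound 4 is expected to remain at the limit, the step from compound 3 being estimated as a step that the limit leaves unreadable from compound 3 to compound 4. The estimate for compound 4 is 150000 nM, ranging from 30000 nM to 1000000 nM.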

Compound 4, half-maximal inhibitory concentration: > 100000 nM
Compound 4 was reported as a limit; the forecaster's own chance of this, stated with the estimate: 85%; the middle value does not contradict the limit.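

Going by these compounds alone, no step from compound 1, compound 2 or compound 3 to compound 4 can be read in this assay, because all four compounds share one limit: (the limit of > 100000 nM in this assay, at which 4 of the 4 values shown sit). The compounds shown leave open which group on the carbonyl carbon, if any, would give a measurable value.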